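Trifluoromethoxyphenyl for Chlorofluorophenyl: Tolerance on Vero Cells

The compounds below may be only part of what the source reports. "The series", "measured", "known", "first", "only" and "open" are said of these compounds alone.

Compound 1 is `COc1nc(-c2ccc(Cl)cc2)ccc1[C@@H](c1ccccc1)[C@@](O)(CCN(C)C)c1cccc2ccccc12`. In a toxicity assay on Vero cells (Chlorocebus sabaeus) for cytotoxicity (a lower number here means that less compound is tolerated, a higher number that more compound is tolerated), compound 1 gives > 50 ug/mL, a limit of the assay.
Compound 2 is `COc1ccc(-c2ccc([C@@H](c3ccccc3)[C@@](O)(CCN(C)C)c3cccc4ccccc34)c(OC)n2)cc1`. In this assay compound 2 gives > 50 ug/mL, again a limit.
Compound 3 is `COc1nc(-c2ccc(Cl)c(F)c2)ccc1[C@@H](c1ccccc1)[C@@](O)(CCN(C)C)c1cccc2ccccc12`. In this assay compound 3 gives > 50 ug/mL, also a limit.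

Compound 3 therefore stands at the upper edge of what this assay could report, and the same holds for every value shown: the limit of > 50 ug/mL in this assay, at which 3 of the 3 values shown sit. The steps that join the measured compounds, a step that the two limits leave unreadable from compound 1 to compound 2, a step that the two limits leave unreadable from compound 1 to compound 3 and a step that the two limits leave unreadable from compound 2 to compound 3, cannot be read in size, since both ends of each lie at the limit.

Compound 4, `COc1nc(-c2ccc(OC(F)(F)F)cc2)ccc1[C@@H](c1ccccc1)[C@@](O)(CCN(C)C)c1cccc2ccccc12`, has not yet been tested in this assay. It differs from compound 3 in one place: 4-(trifluoromethoxy)phenyl in place of 4-chloro-3-fluorophenyl on an aromatic carbon. The measured steps bear on this change only in that every exchange on that aromatic carbon so far, whether methoxy, chloro or fluoro, left the value at the limit. For the measured compounds named here, no step of readable size is available, so no shift beyond the scatter is expected; the step that the limit leaves unreadable from compound 3 to compound 4 is estimated to be flat. Compound 4 is expected to give about 60 ug/mL in this assay, within 30 ug/mL to 120 ug/mL, most likely reported again as a limit.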

Compound 4, half-maximal cytotoxic concentration: > 50 ug/mL
Compound 4: only a limit was reported; the forecaster's own chance of this, stated with the estimate: 80%; the middle value is on the limit's open side.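

In this assay compound 4 gives > 50 ug/mL, which is a limit. No step from compound 1, compound 2 or compound 3 to compound 4 can be read in size, as both ends of each lie at the same edge: the limit of > 50 ug/mL in this assay, at which 4 of the 4 values shown sit.

The compounds shown leave open where the half-maximal cytotoxic concentration of any of the four lies, and whether the exchanged groups differ at all in this assay.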